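Replacing cyclopropyl with 2,4-difluorophenyl on compound 3

The source may hold more compounds than are shown below. What is called first, only, known or untested is meant among the compounds shown, and "the series" means these compounds.

In a functional assay on V79 cells (Cricetulus griseus) for cytotoxicity, read by colony formation (a higher number here means a weaker inhibitor, a lower number a stronger inhibitor), compound 3 (`CC1(N)CCN(c2c(F)cc3c(=O)c(C(=O)O)cn(C4CC4)c3c2C(F)(F)F)C1`) gives 110 ug/mL and holds the lower of the two single numbers in this small set. Compound 2 (`COc1c(N2CCC(C)(N)C2)c(F)cc2c(=O)c(C(=O)O)cn(-c3ccc(F)cc3F)c12`) gives 250 ug/mL as the other single number, higher by more than the usual scatter. Compound 1 (`NC1CCN(c2c(F)cc3c(=O)c(C(=O)O)cn(C4CC4)c3c2C(F)(F)F)C1`) gives 300 ug/mL; 300 ug/mL; 300 ug/mL (3 entries) over repeated entries and is therefore left out of this ranking.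

The next compound is compound 4 (`CC1(N)CCN(c2c(F)cc3c(=O)c(C(=O)O)cn(-c4ccc(F)cc4F)c3c2C(F)(F)F)C1`), in which 2,4-difluorophenyl stands in place of cyclopropyl on an aromatic nitrogen (2,4-difluorophenyl in place of cyclopropyl on an aromatic nitrogen) and the rest of compound 3 is kept.

Going by the values given here, no measured pair isolates this change, so the step has no direct precedent. Among the compounds with values here, the only guide is compound 2, which carries the same 2,4-difluorophenyl and gives 250 ug/mL as its value, although that single value cannot separate this group from the rest of compound 2. A small rise in the number is therefore expected in this assay, pointing to a slightly weaker inhibitor but staying within the scatter. The expected change is a 1.5-fold higher number from compound 3 to compound 4 (0.16 log units; within the scatter) on this estimate. The estimate for compound 4 is 160 ug/mL (expected range 70 ug/mL to 320 ug/mL).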

Compound 4, half-maximal inhibitory concentration: 18 ug/mL
The estimate for compound 4 lay 8.9-fold (0.95 log units) above the measured number; measured number outside the range, below it.
By their numbers in this assay, from the lowest: compound 4; then compound 3; then compound 2.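

In this assay, going by these compounds alone, 2,4-difluorophenyl in place of cyclopropyl on the aromatic nitrogen gives a 6.1-fold lower number from compound 3 to compound 4 (0.79 log units; beyond the scatter) as the first direct reading of this change, and the step runs towards a stronger inhibitor, which the value of compound 2 alone could not indicate. With 2,4-difluorophenyl held fixed, trifluoromethyl in place of methoxy on an aromatic carbon gives a 14-fold lower number from compound 2 to compound 4 (1.14 log units; beyond the scatter) in this assay, so the higher number of compound 2 cannot be read as a property of 2,4-difluorophenyl alone, and the two groups are seen here to work together only in compound 4. No available measurement accounts for the size of either step, so both remain observations without an explanation.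

From the compounds shown here alone, it remains open whether the step on the aromatic nitrogen depends on the fluorines, which a plain phenyl or a 4-fluorophenyl there would test, and whether it carries over to the core of compound 1. Going by these compounds, it is equally open whether chlorine or a nitrile on the aromatic carbon held by trifluoromethyl in compound 4 would give a number nearer to that of compound 4 or to that of compound 2.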